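Thiophene in place of furan on the saturated ring carbon

The source may report more compounds than this note shows. Statements on the series, on what has been measured and on what is new or still open speak of the compounds shown alone.

Three members of the series have been measured in an assay on membranes from HeLa cells for displacement of a labelled ligand from adenosine receptor A3 (Homo sapiens), read by scintillation counting, with a stated time of 180 min, tested at 1 uM; on this read-out lower numbers stand for less inhibition and higher numbers for more inhibition at the one concentration tested (going by the name of the read-out). Compound 1 `CCSC(=O)C1=C(C)NC(=O)NC1c1cccs1` gives 1%, and compound 2 `CC1=C(C(=O)SC(C)C)C(c2cccs2)NC(=O)N1` gives 1%. Compound 3 `CC1=C(C(=O)OC2CCCC2)C(c2ccco2)NC(=O)N1` gives 14%, the highest of the three numbers; compound 1 sits below it by a gap beyond the scatter, and compound 2 sits below it by the same gap.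

Among the measured compounds shown here, the one measured step is no change at the digits printed from compound 1 to compound 2 (within the scatter). It concerns a methyl on a saturated chain carbon and does not touch the aromatic ring on the saturated ring carbon, so it does not bear on the change considered here.

Compound 4 `CC1=C(C(=O)OC2CCCC2)C(c2cccs2)NC(=O)N1` differs from compound 3 by thiophen-2-yl in place of furan-2-yl on a saturated ring carbon. For the measured compounds named here, no measured pair isolates this swap: compound 1 and compound 2 carry thiophen-2-yl, yet they differ from compound 3 elsewhere as well, so their lower numbers cannot be assigned to the ring alone. With nothing bearing directly on the change, compound 4 is expected to move by a number 4 percentage points lower from compound 3 to compound 4 (within the scatter), meaning no change beyond the scatter or a small decrease. Compound 4 is therefore estimated at 10%, within a range from 0% to 28% in this assay.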

Compound 4, a percentage reported as inhibition, at one concentration (the size of the read-out at that concentration, not a potency): 1%
Compound 4: the middle estimate sits 9 percentage points above what was measured; the measured number falls inside the stated range.
By their numbers in this assay, from the lowest: compounds 1, 2 and 4 (each within the scatter of the next); then compound 3.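

In this assay, the swap on the saturated ring carbon now stands on its own: thiophen-2-yl in place of furan-2-yl with the cyclopentyloxy group kept gives a number 13 percentage points lower from compound 3 to compound 4 (beyond the scatter), so the ring alone accounts for a modest loss that the earlier compounds could not separate from their other differences. With thiophen-2-yl held fixed, the group on the carbonyl carbon makes no visible difference, with cyclopentyloxy in place of isopropylsulfanyl giving no change at the digits printed from compound 2 to compound 4 (within the scatter) and cyclopentyloxy in place of ethylsulfanyl giving no change at the digits printed from compound 1 to compound 4 (within the scatter), so all three thiophen-2-yl compounds read alike and only the furan-2-yl compound 3 stands apart. No supporting data bear on why the furan-2-yl compound reads higher.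

Among the compounds shown here, it remains open whether furan-2-yl would also lift the number with ethylsulfanyl or isopropylsulfanyl on the carbonyl carbon, since only one pair isolates the ring swap and that pair rests on a single concentration. How a phenyl ring or a pyridine ring on the saturated ring carbon would read against furan-2-yl and thiophen-2-yl also stays unanswered.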